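Moving the fluorine: from compound 3 to compound 4

This account rests on a few compounds, and the source may have more. Where it says the series, first, only, none or still open, it means among the compounds named here.

In a functional assay on T47D cells (Homo sapiens) for inhibition (on this read-out lower numbers stand for stronger inhibition and higher numbers for weaker inhibition), compound 1 `Oc1ccc(-c2cc(-c3ccccc3F)cc(-c3ccccc3O)n2)cc1` gives > 50000 nM, which is a limit of the assay and not a number. Compound 2 `Oc1ccc(-c2cc(-c3ccccc3F)cc(-c3cccc(O)c3)n2)cc1` gives 6370 nM, and compound 3 `Oc1ccc(-c2cc(-c3ccccc3F)cc(-c3ccc(O)cc3)n2)cc1` gives 15100 nM, the higher of the two actual numbers. Compound 4 `Oc1ccc(-c2cc(-c3ccc(F)cc3)cc(-c3ccc(O)cc3)n2)cc1` is unmeasured and differs from compound 3 as follows: 4-fluorophenyl in place of 2-fluorophenyl on an aromatic carbon. In short, 4-fluorophenyl stands in place of 2-fluorophenyl. Within the data shown here, no measured step alters the fluorophenyl group. Among the measured compounds shown here, the only guide is the exchange of hydroxyphenyl isomers elsewhere on the core: an at least 7.8-fold lower number from compound 1 to compound 2 (0.89 log units; beyond the scatter), an at least 3.3-fold lower number from compound 1 to compound 3 (0.51 log units; beyond the scatter) and a 2.4-fold higher number from compound 2 to compound 3 (0.37 log units; beyond the scatter). These steps are modest or bounded by the limit and lie at another place, so only a small drop in this assay is expected. The expected change is a 1.5-fold lower number from compound 3 to compound 4 (0.18 log units; within the scatter). Compound 4 is estimated at 10000 nM, with an expected range of 3000 nM to 35000 nM.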

Compound 4, half-maximal inhibitory concentration: 5260 nM
Estimate against measurement, compound 4: 1.9-fold (0.28 log units) above, within the range that was stated.
By their numbers in this assay, from the lowest: compounds 4 and 2 (each within the scatter of the next); then compound 3. At a limit, above all of these: compound 1.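

In this assay, the place of the fluorine on this ring counts: 4-fluorophenyl in place of 2-fluorophenyl gives a 2.9-fold lower number from compound 3 to compound 4 (0.46 log units; beyond the scatter). Among these compounds, this is the first step read at the position opposite the ring nitrogen, and it shows that this position responds to an exchange of isomers with the same atoms. Nothing at hand bears on the origin of this step.

As far as these compounds go, how a plain phenyl, a 4-chlorophenyl or a 4-aminophenyl group would read at this position remains open. Also open, from the compounds shown here alone, is whether the step carries over with the 3-hydroxyphenyl group of compound 2.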